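This account rests on a few compounds, and the source may have more. Where it says the series, first, only, none or still open, it means among the compounds named here.

Of the compounds shown here, three of a shared core have been measured in a functional assay on A2780 cells (Homo sapiens) for antiproliferative activity, read by fluorescence, with a stated time of 72 h; on this read-out lower numbers stand for stronger inhibition and higher numbers for weaker inhibition. Compound 1 `CC(C)(C)C(=O)N1Cc2c(NC(=O)C3CCNCC3)n[nH]c2C1(C)C` carries a piperidine amide on the core and gives 650 nM. Compound 3 `CCN1CCC(C(=O)N2Cc3c(NC(=O)CC(C)C)n[nH]c3C2(C)C)CC1` gives 410 nM in this assay. Compound 2 `CN1CCC(C(=O)N2Cc3c(NC(=O)c4ccc5ccccc5c4)n[nH]c3C2(C)C)CC1`, which bears a naphthalen-2-yl on the carbonyl carbon of the amide, gives 270 nM in this assay, the lowest of the three numbers; its gap to compound 1 lies beyond the usual scatter, while its gap to compound 3 lies within it, so compound 2 and compound 3 cannot be ranked against each other.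

The next compound, compound 4 `CN1CCC(C(=O)N2Cc3c(NC(=O)c4ccncc4)n[nH]c3C2(C)C)CC1`, has not yet been measured. It differs from compound 2 in one place, as follows: pyridin-4-yl in place of naphthalen-2-yl on a carbonyl carbon. The pyridin-4-yl that enters brings one six-membered aromatic ring with one hetero atom and one hydrogen-bond acceptor in place of the two carbon-only rings of the naphthalen-2-yl that leaves.

Within the data shown here, no measured pair in this set shows what such a replacement does, so the expectation rests on the three numbers alone. Compound 4 is expected to give a weaker result than compound 2, with a step of a 2.2-fold higher number from compound 2 to compound 4 (0.35 log units; beyond the scatter) that is estimated to reach beyond the scatter. The estimated value for compound 4 in this assay is 600 nM, with a range from 200 nM to 1800 nM.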

Compound 4, half-maximal inhibitory concentration: 500 nM
The estimate for compound 4 lay 1.2-fold (0.08 log units) above the measured number; the range from low to high includes it.
By their numbers in this assay, from the lowest: compounds 2, 3, 4 and 1 (each within the scatter of the next, the first and the last beyond it).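

Among these compounds, compound 4 gives the first direct reading of a change on this carbonyl carbon, whose other neighbours are the amide-type nitrogen: in this assay, pyridin-4-yl in place of naphthalen-2-yl is a step of a 1.9-fold higher number from compound 2 to compound 4 (0.27 log units; within the scatter). Exchanging two six-membered aromatic rings of carbon only for one six-membered aromatic ring with one hetero atom and one hydrogen-bond acceptor therefore leaves compound 2 and compound 4 unranked, so this position accepts both groups without a change that can be told from the scatter. Nothing available here bears on why these two values lie so close.

This single replacement alters the number of rings and brings in the ring nitrogen at once, so the compounds shown cannot separate what each of these does on their own. A phenyl group on the same carbonyl carbon would keep a single ring of carbon only, while a pyridin-3-yl would keep the ring nitrogen in a different place, and neither is represented among these compounds.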